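The compounds below may be only part of what the source reports. "The series", "measured", "known", "first", "only" and "open" are said of these compounds alone.

Working notes on the series. Compound 1 `CC(C)(C)c1cc(/C=C/C(=O)NCCC2CCN(Cc3ccccc3)CC2)cc(C(C)(C)C)c1O` carries a benzyl group on the ring nitrogen; in a functional assay, read by spectrophotometry, with a stated time of 30 min (a lower number here means a stronger inhibitor, a higher number a weaker inhibitor), compound 1 gives 81700 nM. Two neighbours with a changed benzyl ring are measured: compound 2 `CC(C)(C)c1cc(/C=C/C(=O)NCCC2CCN(Cc3ccc(F)cc3F)CC2)cc(C(C)(C)C)c1O` gives 62400 nM in this assay, and compound 3 `CC(C)(C)c1cc(/C=C/C(=O)NCCC2CCN(Cc3ccc(Br)cc3)CC2)cc(C(C)(C)C)c1O` gives 85600 nM. Compound 1 thus sits among three numbers that all lie within the scatter of one another: a 1.3-fold lower number from compound 1 to compound 2 (0.12 log units; within the scatter), a 1.0-fold higher number from compound 1 to compound 3 (0.02 log units; within the scatter), and a 1.4-fold higher number from compound 2 to compound 3 (0.14 log units; within the scatter).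

Compound 4 `CC(C)(C)c1cc(/C=C/C(=O)NCCC2CCN(Cc3cccc([N+](=O)[O-])c3)CC2)cc(C(C)(C)C)c1O` is not yet measured. Against compound 1 the change is nitro in place of hydrogen on an aromatic carbon. Within the data shown here, the steps that bear on it are the two other substitutions on the same aromatic ring of the benzyl group, which gave a 1.0-fold higher number from compound 1 to compound 3 (0.02 log units; within the scatter) and a 1.3-fold lower number from compound 1 to compound 2 (0.12 log units; within the scatter); neither moved the number beyond the scatter. Among the measured compounds shown here, no step beyond the scatter is known at all, so nothing here argues for a shift in either direction. Compound 4 is therefore expected to give a number close to that of compound 1, with a 1.0-fold lower number from compound 1 to compound 4 (0.01 log units; within the scatter) inside the scatter. The estimate for compound 4 in this assay is 80000 nM, with a range from 40000 nM to 160000 nM.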

Compound 4, half-maximal inhibitory concentration: 78100 nM
Compound 4: the middle estimate sits 1.0-fold (0.01 log units) above what was measured, within the range that was stated.
By their numbers in this assay, from the lowest: compounds 2, 4, 1 and 3 (each within the scatter of the next).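

In this assay a substituent meta to a large group on the benzyl ring, here nitro, gives a 1.0-fold lower number from compound 1 to compound 4 (0.02 log units; within the scatter), so this position also shows no shift beyond the scatter. The 3-nitrophenyl compound also stays close to its two substituted neighbours, with a 1.1-fold lower number from compound 3 to compound 4 (0.04 log units; within the scatter) and a 1.3-fold higher number from compound 2 to compound 4 (0.10 log units; within the scatter), so it cannot be separated from the 4-bromophenyl or 2,4-difluorophenyl variants. Nothing available explains why these changes leave the number within the scatter.

From the compounds shown here alone, whether an amine or a carboxylic acid on this ring would move the number beyond the scatter remains open. Also open, going by these compounds, is whether a longer chain between the ring nitrogen and the aromatic ring, or a change to the shared core outside the benzyl group, would do so.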